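Saturating the Furan Ring on a Cytotoxicity Screen

A few compounds are considered here, and "the series" means these few. Any claim that something is new, unique, unknown or untested is made for them only; others in the source may bear on it.

Of the compounds shown here, two sharing one core have been tested in an ADME assay on NHDF cells (Homo sapiens) for cytotoxicity, read by neutral red uptake, with a stated time of 24 h, tested at 15.6 uM; a lower number here means a weaker effect, a higher number a stronger effect of the compound at the concentration tested. Compound 1, `c1csc(CNc2ncnc3c2ncn3C2CCCO2)c1`, gives 100%. Compound 2, `Clc1nc(NCc2ccco2)c2ncn(C3CCCO3)c2n1`, gives 104%. Compound 2 thus shows the higher of the two numbers, but the gap to compound 1 lies within the scatter, so the two results cannot be told apart.

Compound 3, `Clc1nc(NCC2CCCO2)c2ncn(C3CCCO3)c2n1`, has not been measured. It differs from compound 2 in one place: oxolan-2-yl in place of furan-2-yl on a saturated chain carbon bound to a nitrogen on an aromatic ring. For the measured compounds named here, nothing about this particular change has been measured before, so no directly comparable step is available.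

Given that compound 2 gives 104%, near the top of the scale, the expected step of a number 6 percentage points lower from compound 2 to compound 3 (within the scatter) is none beyond the scatter. Compound 3 is therefore estimated at 98%, within a range of 82% to 110%.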

Compound 3, a percentage reported as activity, at one concentration (the size of the read-out at that concentration, not a potency): 101%
Compound 3: the middle estimate sits 3 percentage points below what was measured, within the range that was stated.
By their numbers in this assay, from the lowest: compounds 1, 3 and 2 (each within the scatter of the next).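

In this assay, oxolan-2-yl in place of furan-2-yl on a saturated chain carbon bound to a nitrogen on an aromatic ring leaves the read-out a number 3 percentage points lower from compound 2 to compound 3 (within the scatter) and so the two compounds cannot be told apart. At this position, exchanging a five-membered aromatic ring for a five-membered non-aromatic ring produces no change that this screen can detect. No separate measurement is available to explain this result.

Both compounds read near the top of the scale. Going by these compounds, a real difference between them could also go unseen, and it remains open whether an amine, a carboxylic acid or a longer chain at this place would lower the number. On these data alone, whether the same ring exchange behaves alike on the core of compound 1 also remains open.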